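Carbonyl in place of benzyl on the ring amine nitrogen

This account rests on a few compounds, and the source may have more. Where it says the series, first, only, none or still open, it means among the compounds named here.

Going by the values given here, compound 1 `[O-][S+](CCNC1CCN(Cc2ccc(F)cc2)CC1)C(c1ccc(F)cc1)c1ccc(F)cc1` gives 50.6 nM in an assay on membranes from striatum (strain Sprague-Dawley) for displacement of a labelled ligand from sodium-dependent dopamine transporter (Rattus norvegicus), read by scintillation counting, with a stated time of 120 min (a lower number here means a stronger inhibitor, a higher number a weaker inhibitor), the lowest of the two numbers measured so far. Compound 2 `O=C(c1cc2ccccc2o1)N1CCC(NCCSC(c2ccc(F)cc2)c2ccc(F)cc2)CC1` gives 115 nM in this assay, a number beyond the scatter above that of compound 1; the two structures differ in more than one place, so no single step can be read from this pair. Compound 3 `O=C(c1ccc(F)cc1)N1CCC(NCC[S+]([O-])C(c2ccc(F)cc2)c2ccc(F)cc2)CC1` is not yet measured. It differs from compound 1 in one place: (4-fluorophenyl)carbonyl in place of 4-fluorobenzyl on an amine nitrogen in a ring. Among the compounds with values here, no measured pair isolates this change. A shift toward a weaker inhibitor is nonetheless expected because compound 2 gives 115 nM while carrying a carbonyl on that same ring nitrogen, although compound 2 also differs at the sulfur. The expected step is a 2.4-fold higher number from compound 1 to compound 3 (0.38 log units; beyond the scatter), beyond the scatter. Compound 3 is estimated at 120 nM, with a range from 40 nM to 400 nM.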

Compound 3, inhibition constant: 77.2 nM
Compound 3: middle estimate off by 1.6-fold (0.19 log units), on the high side, within the range that was stated.
By their numbers in this assay, from the lowest: compounds 1, 3 and 2 (each within the scatter of the next, the first and the last beyond it).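

In this assay, going by these compounds alone, (4-fluorophenyl)carbonyl in place of 4-fluorobenzyl on an amine nitrogen in a ring gives the first single-place step, a 1.5-fold higher number from compound 1 to compound 3 (0.18 log units; within the scatter). With the rest of the core of compound 1 held fixed, this position therefore accepts the carbonyl, and with it one hydrogen-bond acceptor, with no difference that can be told from the scatter; the weaker inhibition expected for this change does not appear in this pair. Nothing measured here offers a reason for this result.

Still open, going by these compounds, is the contribution of the sulfur, since the sulfur of compound 2 and its group on the ring nitrogen cannot be read apart. Also open, on these data alone, is how a sulfone at that sulfur, or an acetyl or phenethyl group on the ring nitrogen, would read.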